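Methyl for trifluoromethyl: working notes on compound 4

The source may hold more compounds than are shown below. What is called first, only, known or untested is meant among the compounds shown, and "the series" means these compounds.

In a functional assay on HL-60 cells (Homo sapiens) for antiproliferative activity, with a stated time of 24 h (a higher number here means a weaker inhibitor, a lower number a stronger inhibitor), compound 3 `NC(=O)c1c(NC(=O)c2ccc(C(F)(F)F)cc2)sc2c1CCN(Cc1ccc(Cl)cc1Cl)C2` gives 14900 nM. Compound 1 `NC(=O)c1c(NC(=O)c2ccccc2Cl)sc2c1CCN(Cc1ccc(Cl)cc1Cl)C2` gives 8010 nM, and these two values lie within the scatter of each other. Compound 2 `NC(=O)c1c(NC(=O)c2ccc(C(F)(F)F)cc2)sc2c1CCN(Cc1ccc(Cl)cc1)C2` is reported only as a limit, > 50000 nM.

Compound 4 `Cc1ccc(C(=O)Nc2sc3c(c2C(N)=O)CCN(Cc2ccc(Cl)cc2Cl)C3)cc1` is not yet measured. It carries methyl in place of trifluoromethyl on an aromatic carbon, para to a large group (methyl in place of trifluoromethyl on an aromatic carbon). Within the data shown here, no measured pair tests this exchange directly.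

The nearest evidence is a 1.9-fold higher number from compound 1 to compound 3 (0.27 log units; within the scatter), where 4-(trifluoromethyl)phenyl stands in place of 2-chlorophenyl on a carbonyl carbon. Among the measured compounds shown here, this is the only measured change in the group on the carbonyl carbon, and it rests on a single pair. The other measured change, an at least 3.3-fold lower number from compound 2 to compound 3 (0.52 log units; beyond the scatter), has chloro in place of hydrogen on an aromatic carbon. It is larger, but it lies at a different place in the structure and does not touch the group that changes here, so it carries little weight for this estimate.

The expected step is a 1.2-fold lower number from compound 3 to compound 4 (0.09 log units; within the scatter), with no change beyond the scatter anticipated. For compound 4 the estimated value is 12000 nM, with an expected range of 5000 nM to 32000 nM.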

Compound 4, half-maximal inhibitory concentration: 19900 nM
The estimate for compound 4 lay 1.7-fold (0.22 log units) below the measured number; the measured number falls inside the stated range.
By their numbers in this assay, from the lowest: compounds 1, 3 and 4 (each within the scatter of the next, the first and the last beyond it). At a limit, above all of these: compound 2.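

In this assay, among these compounds, a 1.3-fold higher number from compound 3 to compound 4 (0.13 log units; within the scatter) gives the first direct reading at this place, on an aromatic carbon para to a large group: methyl and trifluoromethyl cannot be told apart here, although one heavy atom replaces four. The change from 2-chlorophenyl reads differently with the new group, since a 2.5-fold higher number from compound 1 to compound 4 (0.40 log units; beyond the scatter) is modest but beyond the scatter, whereas a 1.9-fold higher number from compound 1 to compound 3 (0.27 log units; within the scatter) stays within it, so compound 1 can be separated from compound 4 but not from compound 3, and compounds 3 and 4 cannot be separated from each other. No measured property among the data shown bears on this exchange, and the result therefore remains a statement about the numbers alone.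

As far as these compounds go, whether this place tolerates only these two small carbon-based groups remains open, as an amine, a carboxylic acid or a longer chain at the same position could still move the number beyond the scatter. Compound 2 is only a limit of > 50000 nM in this assay, and it offers no number against which the methyl exchange could be tested on the form of the core carrying one chloro fewer.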